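From hydroxy to methoxy: an expected step in the series

The source may hold more compounds than are shown below. What is called first, only, known or untested is meant among the compounds shown, and "the series" means these compounds.

Measured so far:
compound 1 `CN1CCCC1c1cc2ccccc2o1` — 19400 nM
compound 2 `CN1CCCC1c1cc2cc(O)ccc2o1` — > 100000 nM

In an assay on membranes from HEK293 cells for displacement of a labelled ligand from Neuronal acetylcholine receptor; alpha3/beta4 (Rattus norvegicus), with a stated time of 3 h (a lower number here means a stronger inhibitor, a higher number a weaker inhibitor), compound 1 gives 19400 nM. For compound 2 this assay returns only a limit, > 100000 nM, and no number; its position among the measured compounds is therefore known only as a bound (the limit of > 100000 nM in this assay, at which 1 of the 2 values shown sits). Within the data shown here, the one step measured, an at least 5.1-fold higher number from compound 1 to compound 2 (0.71 log units; beyond the scatter), shows that adding hydroxy on the aromatic carbon weakened binding clearly.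

Compound 3 `COc1ccc2oc(C3CCCN3C)cc2c1` carries the change (methyl in place of hydrogen on an oxygen on an aromatic ring), so the same difference read one bond further out is hydroxy to methoxy. Among the measured compounds shown here, the only step that bears on this change is an at least 5.1-fold higher number from compound 1 to compound 2 (0.71 log units; beyond the scatter); no measured pair shows the methoxy itself. Since compound 2 sits at a limit, the step to compound 3 can only be bounded from one side. The expectation is that the methoxy compound 3 lands between the two measured values, with a real chance that this assay again reports only a limit for it. The estimated step from compound 2 to compound 3 in this assay is an at least 1.6-fold lower number from compound 2 to compound 3 (0.22 log units; that floor lies within the scatter). Compound 3 is expected to give about 60000 nM in this assay, within 15000 nM to 200000 nM.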

Compound 3, inhibition constant: > 100000 nM
Compound 3: no number, only a limit; the forecaster's own chance of this, stated with the estimate: 40%; middle value at least 1.6-fold (0.22 log units) from the limit.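

In this assay compound 3 returns only a limit, > 100000 nM, and no number. Adding methoxy to the shared core gives an at least 5.1-fold higher number from compound 1 to compound 3 (0.71 log units; beyond the scatter), which stands alongside an at least 5.1-fold higher number from compound 1 to compound 2 (0.71 log units; beyond the scatter) and shows that the weakening at this position is not confined to the free hydroxy: capping the oxygen with methyl does not bring back measurable binding in this series. The hydroxy to methoxy step itself cannot be read, as compound 2 and compound 3 stand at the same limit and any difference in their binding stays hidden: the limit of > 100000 nM in this assay, at which 2 of the 3 values shown sit.

The compounds shown leave open how far past that limit compound 2 and compound 3 lie, and so whether methyl on this oxygen changes binding at all. They also leave open whether the loss belongs to oxygen-linked groups in general or to any group at this position, a question that a fluorine, an amine or a longer chain such as ethoxy in the same place on the core of compound 1 would address in this assay.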